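Butylamino for Pentyl on a Sulfonyl Sulfur

This account rests on a few compounds, and the source may have more. Where it says the series, first, only, none or still open, it means among the compounds named here.

Of the compounds shown here, three with a shared core have been measured in a functional assay for inhibition, with Homo sapiens as the target (a higher number here means a weaker inhibitor, a lower number a stronger inhibitor), and they differ only in the group on an amine nitrogen. Compound 1 `CS(=O)(=O)N[C@@H](CNC(=O)c1ccc2c(c1)C(=O)N(CCC1CCNCC1)C2)C(=O)O` gives 14 nM, compound 2 `CCCCCS(=O)(=O)N[C@@H](CNC(=O)c1ccc2c(c1)C(=O)N(CCC1CCNCC1)C2)C(=O)O` gives 9 nM and compound 3 `CCCCCC(=O)N[C@@H](CNC(=O)c1ccc2c(c1)C(=O)N(CCC1CCNCC1)C2)C(=O)O` gives 13 nM. Compound 2 stands within the scatter of both others, so its number cannot be separated from theirs.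

Compound 4 `CCCCNS(=O)(=O)N[C@@H](CNC(=O)c1ccc2c(c1)C(=O)N(CCC1CCNCC1)C2)C(=O)O` has not yet been measured. It differs from compound 2 by butylamino in place of pentyl on a sulfonyl sulfur.

Within the data shown here, no measured step makes this exact change, and no measured compound carries a nitrogen substituent on the sulfonyl sulfur. The closest evidence comes from three other changes in the same region. Lengthening the sulfonyl chain gave a 1.6-fold lower number from compound 1 to compound 2 (0.19 log units; within the scatter), while the exchange of sulfonyl for carbonyl gave a 1.4-fold higher number from compound 2 to compound 3 (0.16 log units; within the scatter). The exchange of methylsulfonyl for pentylcarbonyl gave a 1.1-fold lower number from compound 1 to compound 3 (0.03 log units; within the scatter). All three steps lie within the scatter, so no step beyond the scatter is expected here, and no direction can be called. The expected step is a 1.2-fold higher number from compound 2 to compound 4 (0.09 log units; within the scatter). For compound 4 the estimated value is 11 nM, with an expected range from 5 nM to 25 nM.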

Compound 4, half-maximal inhibitory concentration: 19 nM
Estimate against measurement, compound 4: 1.7-fold (0.24 log units) below; measured number inside the range.
By their numbers in this assay, from the lowest: compounds 2, 3, 1 and 4 (each within the scatter of the next, the first and the last beyond it).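

In this assay, among these compounds, the sulfonyl sulfur becomes a place where a change can be read: a 2.1-fold higher number from compound 2 to compound 4 (0.32 log units; beyond the scatter) is the first step to pass beyond the scatter, though only modestly. The step comes with a swap of pentyl for butylamino, which has the same count of heavy atoms but brings one nitrogen and one hydrogen-bond donor in place of one carbon. The separation holds only against compound 2, as a 1.5-fold higher number from compound 3 to compound 4 (0.16 log units; within the scatter) and a 1.4-fold higher number from compound 1 to compound 4 (0.13 log units; within the scatter) both stay within the scatter, so nothing sets compound 4 apart from the pentylcarbonyl or methylsulfonyl compounds. Nothing in the data shown accounts for the step from pentyl to butylamino.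

The compounds shown leave open whether the step follows the nitrogen itself or the shorter butyl chain, as pentyl and butylamino differ in both at once. A butyl group on the sulfonyl sulfur would address the chain, while methyl(butyl)amino would keep the nitrogen without its hydrogen, and neither group stands among these compounds.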